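The compounds below may be only part of what the source reports. "The series", "measured", "known", "first", "only" and "open" are said of these compounds alone.

Compound 1 `Cc1c(C)c2c(c(C)c1OC(=O)CCC(=O)NC1CC(C)(C)N([O])C(C)(C)C1)CC[C@@](C)(CCC[C@H](C)CCC[C@H](C)CCCC(C)C)O2`: 53000 nM
Compound 2 `Cc1c(C)c2c(c(C)c1O)CCC(C)(C(=O)NC1CC(C)(C)N([O])C(C)(C)C1)O2`: 55000 nM
Compound 3 `Cc1c(C)c2c(c(C)c1OC(=O)CCC(=O)O)CCC(C)(C(=O)NCC1CC(C)(C)N([O])C1(C)C)O2`: > 300000 nM (a limit)

In a functional assay on MT4 cells (Homo sapiens) for cytotoxicity, read by MTT assay, with a stated time of 72 h (on this read-out lower numbers stand for stronger inhibition and higher numbers for weaker inhibition), compound 1 gives 53000 nM, and compound 2 gives 55000 nM, the two lying within the scatter of each other. The entry for compound 3, > 300000 nM, is a limit of the assay and not a number.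

Compound 4 `Cc1c(C)c2c(c(C)c1OC(=O)CCC(=O)NCC1CC(C)(C)N([O])C1(C)C)CC[C@@](C)(CCC[C@H](C)CCC[C@H](C)CCCC(C)C)O2` differs from compound 1 by a group of 11 heavy atoms (9 carbon, 1 nitrogen, 1 oxygen; one five-membered non-aromatic ring with 1 hetero atom) in place of a group of 11 heavy atoms (9 carbon, 1 nitrogen, 1 oxygen; one six-membered non-aromatic ring with 1 hetero atom), on an amide-type nitrogen. Within the data shown here, no measured pair shows this exchange alone, so in this assay a step no larger than the scatter is expected, with no firm direction, starting from compound 1 at 53000 nM. Compound 4 is estimated at 65000 nM, with an expected range of 25000 nM to 170000 nM. The estimate means an expected step of a 1.2-fold higher number from compound 1 to compound 4 (0.09 log units; within the scatter).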

Compound 4, half-maximal inhibitory concentration: 92000 nM
Compound 4: middle estimate off by 1.4-fold (0.15 log units), on the low side; low and high end bracket the measured number.
By their numbers in this assay, from the lowest: compounds 1, 2 and 4 (each within the scatter of the next). At a limit, above all of these: compound 3.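

In this assay, among these compounds, the first comparison of compounds that differ in one place is a 1.7-fold higher number from compound 1 to compound 4 (0.24 log units; within the scatter), with the five-membered non-aromatic ring taking the place of the six-membered one on the amide-type nitrogen. At this position, this read-out therefore does not separate the two rings. Nothing shown bears on a cause for this step.

As far as these compounds go, it remains open whether a plain cyclohexyl ring, lacking the ring nitrogen and its oxygen, would give a different number on this nitrogen. Also open, from the compounds shown here alone, is whether the same ring exchange alone would behave alike on the cores of compound 2 and compound 3.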